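The source may report more compounds than this note shows. Statements on the series, on what has been measured and on what is new or still open speak of the compounds shown alone.

Compound 1 `O=C(/C=C/c1ccc([N+](=O)[O-])cc1)Nc1cc(-c2ccccc2)[nH]n1` and compound 2 `O=C(/C=C/c1ccc(Br)cc1)Nc1cc(-c2ccc(Br)cc2)[nH]n1` share one core. In a functional assay on A549 cells (Homo sapiens) for antiproliferative activity, read by MTT assay, with a stated time of 48 h (on this read-out higher numbers stand for weaker inhibition and lower numbers for stronger inhibition), compound 1 gives 970 nM, the lower of the two numbers, while compound 2 gives 1360 nM; the gap between them lies within the usual scatter, so neither can be called the stronger. Compound 3 `Cc1ccc(/C=C/C(=O)Nc2cc(-c3ccccc3)[nH]n2)cc1` has not been measured. It differs from compound 1 in one place: methyl in place of nitro on an aromatic carbon. Among the compounds with values here, no measured pair shows this change, so its effect is unknown. The expected step is a 1.5-fold higher number from compound 1 to compound 3 (0.19 log units; within the scatter), a small rise that may stay within the scatter. Compound 3 is therefore estimated at 1500 nM, with a likely range from 500 nM to 4500 nM.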

Compound 3, half-maximal inhibitory concentration: 1770 nM
Estimate against measurement, compound 3: 1.2-fold (0.07 log units) below; measured number inside the range.
By their numbers in this assay, from the lowest: compounds 1, 2 and 3 (each within the scatter of the next).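

In this assay, within the data shown here, the swap of nitro for methyl on this aromatic carbon, para to a large group, gives a 1.8-fold higher number from compound 1 to compound 3 (0.26 log units; within the scatter) and is the first direct reading of this change. At this position the two groups cannot be told apart, although nitro has 3 heavy atoms and 2 hydrogen-bond acceptors, while methyl has 1 heavy atom and none. No measurement shown here offers an explanation for this result. As far as these compounds go, whether an amine, a carboxylic acid or a longer chain on this carbon would shift the number beyond the scatter remains open.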